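Replacing the ethoxy of compound 1 with methylcarbamoyl

The source may report more compounds than this note shows. Statements on the series, on what has been measured and on what is new or still open speak of the compounds shown alone.

compound 1 `CCOc1ccc(-c2cncnc2-c2cc(OC)c(OC)c(OC)c2)cc1`: 640 nM
compound 2 `CCOc1ccc(-c2cncnc2-c2cc(OC)c(OC)c(OC)c2)cc1Cl`: 150 nM
compound 3 `CNC(=O)c1ccc(-c2cncnc2-c2cc(OC)c(OC)c(OC)c2)cc1`: not yet measured

In a functional assay on SiHa cells (Homo sapiens) for antiproliferative activity, read by CCK-8 assay, with a stated time of 72 h (on this read-out higher numbers stand for weaker inhibition and lower numbers for stronger inhibition), compound 1 stands at the higher of the two numbers (640 nM). Compound 3 carries methylcarbamoyl in place of ethoxy on an aromatic carbon. Going by the values given here, the only measured step (a 4.3-fold lower number from compound 1 to compound 2 (0.63 log units; beyond the scatter)) is chloro in place of hydrogen and keeps the ethoxy, so it bears on this change only indirectly. Among the compounds with values here, no measured step covers the loss of the ethoxy. A move toward weaker inhibition in this assay is expected, larger than that measured step, and the estimated step is (a 3.9-fold higher number from compound 1 to compound 3 (0.59 log units; beyond the scatter)). Compound 3 is estimated at 2500 nM (expected range 500 nM to 12000 nM).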

Compound 3, half-maximal inhibitory concentration: 10900 nM
Compound 3: middle estimate off by 4.4-fold (0.64 log units), on the low side; the range from low to high includes it.
By their numbers in this assay, from the lowest: compound 2; then compound 1; then compound 3.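

In this assay the position para to a large group proved far from indifferent to its substituent: methylcarbamoyl in place of ethoxy gives a 17-fold higher number from compound 1 to compound 3 (1.23 log units; beyond the scatter) and so a large move toward weaker inhibition. The swap trades an ether for an amide carrying one hydrogen-bond donor, and nothing measured accounts for the loss. Open, going by these compounds, is whether the ethoxy itself matters or the methylcarbamoyl is what harms. A methoxy, a longer alkoxy chain, a primary carboxamide or a carboxylic acid here would begin to separate these.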